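The source may report more compounds than this note shows. Statements on the series, on what has been measured and on what is new or still open speak of the compounds shown alone.

Of the compounds shown here, two of a shared core have been measured in a functional assay on SK-MEL-2 cells (Homo sapiens) for inhibition, read by sulforhodamine B assay, with a stated time of 48 h; on this read-out higher numbers stand for weaker inhibition of growth and lower numbers for stronger inhibition of growth. Compound 1 `CCOC(=O)[C@H](CCC(=O)O)NC(=O)c1ccc(CNc2nc3cc(N)cc(N)c3nc2-c2ccccc2)cc1` carries a longer substituted arm on the aromatic nitrogen and in this assay gives 77600 nM. Compound 2 `Nc1cc(N)c2nc(-c3ccccc3)c(NCc3ccc(Cl)c(Cl)c3)nc2c1` bears a 3,4-dichlorophenyl on the saturated chain carbon bound to that nitrogen and in this assay gives 4270 nM, the lowest of the two numbers, with compound 1 standing at a higher number, a gap beyond the scatter. Compound 3 `COc1ccc(CNc2nc3cc(N)cc(N)c3nc2-c2ccccc2)cc1OC` is the third member and has not yet been measured in this assay. It differs from compound 2 in one place: 3,4-dimethoxyphenyl in place of 3,4-dichlorophenyl on a saturated chain carbon bound to a nitrogen on an aromatic ring. Within the data shown here, no measured pair shows this exact change, so the size of the step is open. The replacement of two chlorines by two methoxy groups, bringing in two hydrogen-bond acceptors where compound 2 has none, is expected to move the number upward by a modest margin, plausibly beyond the scatter but far short of the gap to compound 1. Compound 3 is thus estimated at 12000 nM in this assay, within a range of 3500 nM to 45000 nM, a step of a 2.8-fold higher number from compound 2 to compound 3 (0.45 log units; beyond the scatter) that is expected rather than measured.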

Compound 3, concentration for total growth inhibition: 30200 nM
Beside the measured number, compound 3's estimate is 2.5-fold (0.40 log units) below it; measured number inside the range.
By their numbers in this assay, from the lowest: compound 2; then compound 3; then compound 1.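

In this assay, among these compounds, the exchange of 3,4-dichlorophenyl for 3,4-dimethoxyphenyl on a saturated chain carbon bound to a nitrogen on an aromatic ring gives a 7.1-fold higher number from compound 2 to compound 3 (0.85 log units; beyond the scatter), which gives the first direct reading at this position: what this ring carries changes the number, and this exchange moves it towards weaker inhibition of growth. The six-membered aromatic ring of carbon only is present on both sides of the step, so the change lies in what that ring carries, with two chlorine atoms leaving, and two methoxy groups entering that bring two hydrogen-bond acceptors. Nothing measured here bears on why the step has this size.

The single exchange removes the chlorine atoms and adds the methoxy groups together, so the compounds shown cannot separate the part played by each. From the compounds shown here alone, how a phenyl without substituents, or a phenyl carrying an amine or a carboxylic acid, would stand at this place remains open, as does whether the same exchange would give a similar step on another core.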